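This account rests on a few compounds, and the source may have more. Where it says the series, first, only, none or still open, it means among the compounds named here.

Of the compounds shown here, three have been tested in a functional assay on MCF7 cells (Homo sapiens) for antiproliferative activity, read by sulforhodamine B assay, with a stated time of 72 h, tested at 30 uM; on this read-out higher numbers stand for a weaker effect at the one concentration tested and lower numbers for a stronger effect. Compound 1 `COc1cc(Br)cc(/C=C/C(=O)c2ccc(Br)cc2)c1O` gives 48.3% there. Compound 2 `COC(=O)C1=C(N)Oc2ccc(Br)cc2C1CC(=O)c1ccc(Cl)cc1` gives 32.4% in this assay, and compound 3 `COc1cc(Br)cc2c1OC(N)=C(C#N)C2CC(=O)c1ccccc1` gives 36.7%. Compound 3 thus stands second highest of the three numbers: its number lies within the usual scatter of that of compound 2, while the number of compound 1 is higher and beyond the scatter. Compound 4 `COc1cc(Br)cc2c1OC(N)=C(C#N)C2CC(=O)c1ccc(C)cc1` differs from compound 3 in one place: methyl in place of hydrogen on an aromatic carbon. For the measured compounds named here, no pair of measured compounds isolates such a change, so its direction cannot be read from the data. The expected step in this assay is a number 1.7 percentage points lower from compound 3 to compound 4 (within the scatter), none beyond the scatter. Compound 4 is therefore expected to give 35%, between 22% and 50%.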

Compound 4, a percentage reported as activity, at one concentration (the size of the read-out at that concentration, not a potency): 52.8%
Beside the measured number, compound 4's estimate is 17.8 percentage points below it, outside the stated range (above it).
By their numbers in this assay, from the lowest: compounds 2 and 3 (each within the scatter of the next); then compounds 1 and 4 (each within the scatter of the next).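

In this assay, the change from phenyl to 4-methylphenyl brings a number 16.1 percentage points higher from compound 3 to compound 4 (beyond the scatter), so the effect at the one concentration tested weakens when methyl replaces hydrogen at this place. This position on the aromatic ring is therefore not indifferent to one added carbon, although the finding rests on a single pair. Nothing available accounts for the step.

As far as these compounds go, whether the weakening is specific to methyl remains open. An ethyl chain, a fluorine atom, an amine or a carboxylic acid at the same place could give a different result.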